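This account rests on a few compounds, and the source may have more. Where it says the series, first, only, none or still open, it means among the compounds named here.

The compounds here share one core, an ester of a ring-fused alcohol that carries a chain ending in an acid or an amide. Compound 1 `Cc1c(C)c2c(c(C)c1OC(=O)CCC(=O)O)CCC(C)(C(=O)NC1CC(C)(C)N([O])C(C)(C)C1)O2` bears the amide to a six-membered non-aromatic ring. In a functional assay on CEM13 cells (Homo sapiens) for cytotoxicity, read by MTT assay, with a stated time of 72 h (a higher number here means a weaker inhibitor, a lower number a stronger inhibitor), compound 1 reaches only a limit of the assay, > 300000 nM, not a number. Compound 2 `Cc1c(C)c2c(c(C)c1OC(=O)CCC(=O)O)CCC(C)(C(=O)NCC1CC(C)(C)N([O])C1(C)C)O2` carries a five-membered non-aromatic ring instead. In this assay compound 2 likewise gives only a limit, > 300000 nM. Compound 3 `Cc1c(C)c2c(c(C)c1OC(=O)CCC(=O)O)CCC(C)(C(=O)O)O2` has a plain acid on that carbonyl carbon, and in this assay compound 3 gives 191000 nM. The steps of an at least 1.5-fold lower number from compound 1 to compound 3 (0.19 log units; that floor lies within the scatter) and an at least 1.5-fold lower number from compound 2 to compound 3 (0.19 log units; that floor lies within the scatter) are read against the limit of > 300000 nM in this assay, at which 2 of the 3 values shown sit, and each lies within the scatter, so the exchange of an amide for an acid on this core has shown nothing beyond the noise. Compound 4 `Cc1c(C)c2c(c(C)c1OC(=O)CCC(=O)NCC1CC(C)(C)N([O])C1(C)C)CCC(C)(C(=O)NCC1CC(C)(C)N([O])C1(C)C)O2` is the compound still to be measured. It differs from compound 2 in one place: a group of 12 heavy atoms (9 carbon, 2 nitrogen, 1 oxygen; one five-membered non-aromatic ring with 1 hetero atom) in place of one oxygen atom, on a carbonyl carbon. This is the reverse kind of exchange, an acid becoming an amide, on the other chain. With the comparable steps all within scatter, no step beyond the scatter is expected. Compound 4 is therefore estimated at 350000 nM, ranging from 150000 nM to 1000000 nM, an expected step that the limit leaves unreadable from compound 2 to compound 4.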

Compound 4, half-maximal inhibitory concentration: 107000 nM
Compound 4: the middle estimate sits 3.3-fold (0.51 log units) above what was measured; measured number outside the range, below it.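

In this assay, replacing the hydroxy on the carbonyl carbon of the saturated chain with the group of 12 heavy atoms holding a five-membered non-aromatic ring gives an at least 2.8-fold lower number from compound 2 to compound 4 (0.44 log units; beyond the scatter). Among the compounds shown here, this is the first change on the shared core that reads beyond the scatter, so this acid position does respond to an amide, whereas the earlier exchanges on the other chain showed nothing beyond the noise. On these data alone, the real size of the step stays unknown because compound 2 stands only at a limit of the assay, not at a number: the limit of > 300000 nM in this assay, at which 2 of the 4 values shown sit.

The compounds shown leave open whether the ring group itself matters at this position, or whether a simple methyl amide, a methyl ester or the six-membered ring group of compound 1 on the same carbonyl carbon would give a similar step. They also leave open whether a longer chain between the amide nitrogen and the five-membered ring would keep the change.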